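Swapping 4-(methylsulfanyl)phenyl for thiophen-2-yl

This account rests on a few compounds, and the source may have more. Where it says the series, first, only, none or still open, it means among the compounds named here.

In a functional assay on HeLa cells (Homo sapiens) for inhibition, read by MTT assay, with a stated time of 48 h (on this read-out higher numbers stand for weaker inhibition and lower numbers for stronger inhibition), compound 1 `C(=C/c1nc2ccccn2c1Sc1ccccc1)\c1ccccc1` gives 35500 nM, and compound 2 `CSc1ccc(-c2nc3ccccn3c2Sc2ccccc2)cc1` gives 30000 nM. Among the measured compounds shown here, the only measured step is a 1.2-fold lower number from compound 1 to compound 2 (0.07 log units; within the scatter), which lies within the scatter, so compound 2 stands level with the one other measured compound. Compound 3 `c1ccc(Sc2c(-c3cccs3)nc3ccccn23)cc1` carries thiophen-2-yl in place of 4-(methylsulfanyl)phenyl on an aromatic carbon, (thiophen-2-yl in place of 4-(methylsulfanyl)phenyl on an aromatic carbon). The measured step exchanged a group on that same carbon, 4-(methylsulfanyl)phenyl in place of 2-phenylethenyl. For the measured compounds named here, with a 1.2-fold lower number from compound 1 to compound 2 (0.07 log units; within the scatter) as the sole guide, no step beyond the scatter is expected in this assay, and the data suggest no direction. One step is thin evidence, however, so the range is kept wide. The estimated step is a 1.1-fold lower number from compound 2 to compound 3 (0.03 log units; within the scatter). For compound 3 the expected value is 28000 nM, with an estimated range of 11000 nM to 70000 nM.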

Compound 3, half-maximal inhibitory concentration: 19900 nM
For compound 3 the middle estimate is 1.4-fold (0.15 log units) above the measured one, and the stated range covers the measured number.
By their numbers in this assay, from the lowest: compounds 3, 2 and 1 (each within the scatter of the next).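

At this position a five-membered aromatic ring with 1 hetero atom now takes the place of a six-membered aromatic ring of carbon only, and this assay records a 1.5-fold lower number from compound 2 to compound 3 (0.18 log units; within the scatter) as well as a 1.8-fold lower number from compound 1 to compound 3 (0.25 log units; within the scatter) for the exchange with 2-phenylethenyl. All three groups on this carbon therefore stand within the scatter of one another, and this now holds for thiophen-2-yl with its 5 heavy atoms as it does for 4-(methylsulfanyl)phenyl with its 8, which the first two compounds alone could not show. No measurement given here bears on why the change left the number within the scatter.

As far as these compounds go, it remains open whether any group on this carbon can move the number beyond the scatter. An amine or a carboxylic acid in this place would put that question to a different kind of group.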